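The source may hold more compounds than are shown below. What is called first, only, known or untested is meant among the compounds shown, and "the series" means these compounds.

In a functional assay on MCF7 cells (Homo sapiens) for inhibition, read by CCK-8 assay, with a stated time of 72 h (on this read-out higher numbers stand for weaker inhibition and lower numbers for stronger inhibition), compound 1 (`O=C(/C=C/c1cccnc1)NCCCCCCCc1cccc(S(=O)(=O)Nc2ccccc2)c1`) reads 42.6 nM and compound 2 (`Cc1ccc(NS(=O)(=O)c2cccc(CCCCCCNC(=O)/C=C/c3cccnc3)c2)cc1`) reads 1.97 nM as the lower of the two numbers, with the gap between them beyond the scatter. Going by the values given here, compound 2 therefore marks the low end of the numbers so far. Among the compounds with values here, compound 1 and compound 2 differ in more than one place, so the series holds no measured step that isolates a change at the group in question.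

The next compound is compound 3 (`CC(C)(C)c1ccc(NS(=O)(=O)c2cccc(CCCCCCNC(=O)/C=C/c3cccnc3)c2)cc1`), and its difference from compound 2 is tert-butyl in place of methyl on an aromatic carbon in the form of tert-butyl in place of methyl on an aromatic carbon, para to a large group. Within the data shown here, with no measured step to lean on, the expectation rests on where compound 2 sits at 1.97 nM in this small set, which leaves more room for a higher number than for a lower one. The expected change is a 2.5-fold higher number from compound 2 to compound 3 (0.40 log units; beyond the scatter) in the direction of weaker inhibition, of modest size, and a result within the scatter would not be a surprise. For compound 3 the estimate is 5 nM with an expected range from 1 nM to 25 nM in this series.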

Compound 3, half-maximal inhibitory concentration: 26.3 nM
Estimate against measurement, compound 3: 5.3-fold (0.72 log units) below, and the stated range ends below it.
By their numbers in this assay, from the lowest: compound 2; then compounds 3 and 1 (each within the scatter of the next).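

In this assay, going by these compounds alone, tert-butyl in place of methyl on the aromatic carbon para to a large group gives a 13-fold higher number from compound 2 to compound 3 (1.13 log units; beyond the scatter), the first measured change confined to one place. This position is therefore not indifferent to what it carries: the read-out moves beyond the scatter even though the change only takes 1 heavy atom out and puts 4 heavy atoms in, all carbon, with no ring, no hydrogen-bond donors or acceptors, and no net charge on either group. Nothing available bears on what lies behind this shift.

One step gives two points at this position, so it cannot show whether the number climbs gradually with added carbon or jumps only at tert-butyl; ethyl and isopropyl on the same aromatic carbon would separate those two readings. Also open, going by these compounds, is how groups that bring atoms other than carbon, such as methoxy or chlorine, would read here against the methyl of compound 2 at 1.97 nM, and whether a free amine at this carbon would be tolerated at all.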